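A few compounds are considered here, and "the series" means these few. Any claim that something is new, unique, unknown or untested is made for them only; others in the source may bear on it.

Measured so far:
compound 1 `NS(=O)(=O)c1ccc(Nc2nc(N/N=C/c3ccc(C(F)(F)F)cc3)nc(Nc3ccccc3)n2)cc1`: 37200 nM
compound 2 `Cc1nn(-c2ccccc2)cc1/C=N/Nc1nc(Nc2ccccc2)nc(Nc2ccc(S(N)(=O)=O)cc2)n1`: > 100000 nM

In a functional assay on BT-549 cells (Homo sapiens) for inhibition, read by sulforhodamine B assay, with a stated time of 48 h (a higher number here means that more compound is tolerated, a lower number that less compound is tolerated), compound 1 gives 37200 nM. For compound 2 the read-out is only a limit of this assay, > 100000 nM, and not a number. Compound 2 thus sits at the limit of > 100000 nM in this assay, at which 1 of the 2 values shown sits, and its step from the first compound is known only as a bound: an at least 2.6-fold higher number from compound 1 to compound 2 (0.42 log units; beyond the scatter). Compound 3 `NS(=O)(=O)c1ccc(Nc2nc(N/N=C/c3ccccn3)nc(Nc3ccccc3)n2)cc1` has not been measured yet. It differs from compound 2 in one place: pyridin-2-yl in place of 3-methyl-1-phenyl-1H-pyrazol-4-yl on a carbon with a double bond to nitrogen. Among the compounds with values here, the only measured step at this carbon is an at least 2.6-fold higher number from compound 1 to compound 2 (0.42 log units; beyond the scatter), a loss of at least modest size when the aryl group on the imine carbon was exchanged; no step maps the pyridin-2-yl group itself. Because compound 2 stands at a limit, the size of the expected step is uncertain and a return toward numbers like that of compound 1 is as plausible as staying at the limit. Compound 3 is expected to give about 60000 nM in this assay, within 20000 nM to 150000 nM. The estimated step is an at least 1.6-fold lower number from compound 2 to compound 3 (0.22 log units; that floor lies within the scatter).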

Compound 3, concentration lethal to 50% of the cells: > 100000 nM
Compound 3: only a limit was reported; the forecaster's own chance of this, stated with the estimate: 40%; middle value at least 1.6-fold (0.22 log units) from the limit.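

In this assay compound 3 also gives only a limit, > 100000 nM, and not a number. On the carbon with a double bond to nitrogen, pyridin-2-yl in place of 4-(trifluoromethyl)phenyl gives an at least 2.6-fold higher number from compound 1 to compound 3 (0.42 log units; beyond the scatter), so a shift of this kind is no longer tied to 3-methyl-1-phenyl-1H-pyrazol-4-yl alone, even though pyridin-2-yl has fewer heavy atoms than 3-methyl-1-phenyl-1H-pyrazol-4-yl. The step between compound 2 and compound 3 cannot be read, and the series now mostly sits at one ceiling: the limit of > 100000 nM in this assay, at which 2 of the 3 values shown sit.

On these data alone, how far compound 2 and compound 3 lie from each other remains open, as does whether 4-(trifluoromethyl)phenyl is unusual in giving a number here. An unsubstituted phenyl, or a phenyl carrying an amine or a carboxylic acid, on this carbon would show whether readable values return.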